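Shifting the methyl: from compound 1 to compound 4

This account rests on a few compounds, and the source may have more. Where it says the series, first, only, none or still open, it means among the compounds named here.

Within the data shown here, in a functional assay on A2780 cells (Homo sapiens) for inhibition, read by sulforhodamine B assay, with a stated time of 72 h (a higher number here means a weaker inhibitor, a lower number a stronger inhibitor), compound 1 `Cc1ccccc1S(=O)(=O)c1ccc(CNC(=O)c2cc3cnccc3[nH]2)cc1` gives 13 nM, the lower of the two numbers measured so far. Compound 3 `O=C(NCc1ccc(S(=O)(=O)c2ccccc2)cc1)c1cnc2nccn2c1` gives 68 nM, a higher number and a gap beyond the scatter. Compound 2 `Cn1c(C(=O)NCc2ccc(S(=O)(=O)c3ccccc3)cc2)cc2cnccc21` reads > 10000 nM, which is a limit of the assay and not a number.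

Compound 4 `Cc1cccc(S(=O)(=O)c2ccc(CNC(=O)c3cc4cnccc4[nH]3)cc2)c1` has not yet been measured. It has the same atoms as compound 1, joined differently, with 3-methylphenyl in place of 2-methylphenyl on a sulfonyl sulfur. Among the measured compounds shown here, no measured pair isolates this change. The expectation therefore rests on compound 1 at 13 nM, and no shift beyond the scatter is expected in this assay, although a small move towards a higher number is allowed for. The expected size of the change is a 1.4-fold higher number from compound 1 to compound 4 (0.14 log units; within the scatter). For compound 4 the estimated value is 18 nM, with an expected range of 5 nM to 70 nM.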

Compound 4, half-maximal inhibitory concentration: 4 nM
For compound 4 the middle estimate is 4.5-fold (0.65 log units) above the measured one; measured number outside the range, below it.
By their numbers in this assay, from the lowest: compound 4; then compound 1; then compound 3. At a limit, above all of these: compound 2.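

In this assay, 3-methylphenyl in place of 2-methylphenyl on a sulfonyl sulfur gives a 3.3-fold lower number from compound 1 to compound 4 (0.51 log units; beyond the scatter). Among these compounds, this is the first step that isolates a single change, and it shows that activity responds to where the methyl stands on this ring, even though the atoms stay the same. Nothing measured here gives a cause for this step.

From the compounds shown here alone, it remains open whether a methoxy group, a chlorine atom or an ethyl chain in place of the methyl on this ring would follow compound 4 or compound 1. Also open, going by these compounds, is how the shared core of compound 1 and compound 4 performs with a plain phenyl on the sulfonyl sulfur, which would show whether the methyl contributes at all.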